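Side-chain swap on the amide of compound 2

This account rests on a few compounds, and the source may have more. Where it says the series, first, only, none or still open, it means among the compounds named here.

Compound 1 `CC(C)/C=C/C(=O)Nc1cccc(Oc2nc(Nc3ccn(C)n3)nc3c2CSCC3)c1` gives 40100 nM
Compound 2 `COc1ccc(Nc2nc3c(c(Oc4cccc(NC(=O)C=C(C)C)c4)n2)CSCC3)cn1` gives 29200 nM

Both values come from a functional assay on HeLa cells (Homo sapiens) for antiproliferative activity, read by MTT assay, with a stated time of 72 h (a lower number here means a stronger inhibitor, a higher number a weaker inhibitor), and lie within the scatter of each other, so compound 2 stands level with compound 1 on these numbers. Compound 3 `COc1ccc(Nc2nc3c(c(Oc4cccc(NC(=O)/C=C/C(C)C)c4)n2)CSCC3)cn1` differs from compound 2 by 3-methylbut-1-en-1-yl in place of 2-methylprop-1-en-1-yl on a carbonyl carbon with 3-methylbut-1-en-1-yl in place of 2-methylprop-1-en-1-yl on a carbonyl carbon. Among the measured compounds shown here, no measured step covers this change, so no step beyond the scatter is expected in this assay and no direction is favoured. The expected change is a 1.1-fold higher number from compound 2 to compound 3 (0.04 log units; within the scatter) and stays small. For compound 3 the estimate is 32000 nM with an expected range of 14000 nM to 70000 nM for repeated measurements.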

Compound 3, half-maximal inhibitory concentration: 27800 nM
For compound 3 the middle estimate is 1.2-fold (0.06 log units) above the measured one; the range from low to high includes it.
By their numbers in this assay, from the lowest: compounds 3, 2 and 1 (each within the scatter of the next).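

In this assay 3-methylbut-1-en-1-yl in place of 2-methylprop-1-en-1-yl on a carbonyl carbon gives a 1.1-fold lower number from compound 2 to compound 3 (0.02 log units; within the scatter), so the two side chains read level. With that side chain held, 6-methoxypyridin-3-yl in place of 1-methyl-1H-pyrazol-3-yl on a nitrogen on an aromatic ring gives a 1.4-fold lower number from compound 1 to compound 3 (0.16 log units; within the scatter), which also reads level. No measurement on hand offers an explanation for either result.

Still open, on these data alone, is whether a longer chain, a saturated alkyl chain or an amine on the carbonyl carbon would shift the number beyond the scatter.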